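This account rests on a few compounds, and the source may have more. Where it says the series, first, only, none or still open, it means among the compounds named here.

Measured so far in an assay on cells for inhibition of Rho-associated protein kinase 2 (Homo sapiens), read by radiometric assay and 33P incorporation, in the presence of a further agent that is not named here; on this read-out lower numbers stand for stronger inhibition and higher numbers for weaker inhibition:
compound 1 `NCc1ccc(C(=O)Nc2ccncc2F)cc1-c1cccc(NC(=O)c2cccc(C(=O)O)c2)c1`: < 1 nM
compound 2 `NCc1ccc(C(=O)Nc2ccncc2F)cc1-c1cccc(C(=O)Nc2cccc(CC(=O)O)c2)c1`: 1.5 nM
compound 3 `CCCOC(=O)c1ccc(NC(=O)c2cccc(-c3cc(C(=O)Nc4ccncc4F)ccc3CN)c2)cc1`: < 1 nM

The value of compound 3 in this assay is a limit of the assay, not a number; it sits at the limit of < 1 nM in this assay, at which 2 of the 3 values shown sit. Within the data shown here, the only single-point step measured so far is an at least 1.5-fold lower number from compound 2 to compound 3 (0.17 log units; that floor lies within the scatter), whose floor lies within the scatter. Compound 4 `NCc1ccc(C(=O)Nc2ccncc2F)cc1-c1cccc(C(=O)Nc2ccc(CC(=O)O)cc2)c1` differs from compound 3 by carboxymethyl in place of propoxycarbonyl on an aromatic carbon. This change largely undoes the one measured, so the step expected for compound 4 is a return toward the number of compound 2, an at least 1.5-fold higher number from compound 3 to compound 4 (0.17 log units; that floor lies within the scatter), which may itself not exceed the scatter. Compound 4 is therefore estimated at 1.5 nM, with a range from 0.7 nM to 4 nM.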

Compound 4, half-maximal inhibitory concentration: 1.8 nM
The estimate for compound 4 lay 1.2-fold (0.08 log units) below the measured number; the range from low to high includes it.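

Working from this assay, the new result shows that the carboxymethyl group can sit on either ring place without a readable change, since 4-(carboxymethyl)phenyl in place of 3-(carboxymethyl)phenyl gives a 1.2-fold higher number from compound 2 to compound 4 (0.08 log units; within the scatter). The other step, an at least 1.8-fold higher number from compound 3 to compound 4 (0.25 log units; that floor lies within the scatter), is only a floor, so its true size cannot be read and no order between the ester and the acid follows from it: the limit of < 1 nM in this assay, at which 2 of the 4 values shown sit.

Still open, from the compounds shown here alone, is how far below that limit the propoxycarbonyl compound lies. Also open, going by these compounds, is whether an amine or a longer chain ending in a carboxylic acid, at this same place on the ring, would read any differently in this assay.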